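This account rests on a few compounds, and the source may have more. Where it says the series, first, only, none or still open, it means among the compounds named here.

Measured so far:
compound 1 `CCCc1c(OCCCCCCCCC(=O)O)ccc(C(C)=O)c1O` – 5.8
compound 2 `CCCc1c(OCCCCCC(=O)O)ccc(C(C)=O)c1O` – 6

In a functional assay on ileum (Cavia porcellus) for inhibition of cysteinyl leukotriene receptor (Homo sapiens) (a lower number here means a less potent compound, a higher number a more potent compound, by a factor of ten per unit of this negative logarithm), compound 1 gives 5.8, the lower of the two numbers; compound 2 gives 6, and the step of a number 0.20 log units higher from compound 1 to compound 2 (within the scatter) stays within the scatter. Compound 3 `CCCc1c(OCCCCCCCc2nn[nH]n2)ccc(C(C)=O)c1O` differs from compound 1 by 2H-tetrazol-5-yl in place of carboxymethyl on a saturated chain carbon, seven bonds along the chain from an oxygen on an aromatic ring. For the measured compounds named here, the only measured step shortens the chain without changing the acid, so the tetrazolyl replacement itself has no measured counterpart here. The step of a number 0.20 log units higher from compound 1 to compound 3 (within the scatter) is therefore expected to stay within the scatter. Compound 3 is estimated at 6, with a range of 5.4 to 6.6.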

Compound 3, negative logarithm of the antagonist equilibrium constant: 7
Beside the measured number, compound 3's estimate is 1.00 log units below it, outside the stated range (above it).
By their numbers in this assay, from the lowest: compounds 1 and 2 (each within the scatter of the next); then compound 3.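

In this assay, swapping the acid group itself moves the number, which the earlier pair could not show: 2H-tetrazol-5-yl in place of carboxymethyl gives a large step (a number 1.20 log units higher from compound 1 to compound 3 (beyond the scatter)), and the comparison with the shorter carboxylic acid gives a modest one (a number 1.00 log units higher from compound 2 to compound 3 (beyond the scatter)). The earlier pair (a number 0.20 log units higher from compound 1 to compound 2 (within the scatter)) differed only in chain length, with the carboxylic acid kept. No measurement here accounts for the tetrazole result.

Still open, going by these compounds, is whether a shorter or longer chain ending in 2H-tetrazol-5-yl would hold this number. Also open, on these data alone, is how an acyl sulfonamide in the same place would compare.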